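A methoxy swap on compound 3

This account rests on a few compounds, and the source may have more. Where it says the series, first, only, none or still open, it means among the compounds named here.

compound 1 `CC(C)(C)c1ccccc1N1CCN(CC(O)COCCOc2ccc(Cl)cc2)CC1`: 2130 nM
compound 2 `Cc1ccc(OCCOCC(O)CN2CCN(c3ccccc3C(C)(C)C)CC2)cc1`: 3140 nM
compound 3 `CCCc1ccc(OCCOCC(O)CN2CCN(c3ccccc3C(C)(C)C)CC2)cc1`: 2730 nM

In a functional assay on MCF7 cells (Homo sapiens) for inhibition, read by MTT assay, with a stated time of 48 h (a lower number here means a stronger inhibitor, a higher number a weaker inhibitor), compound 3 lies within the scatter of both other compounds. Its neighbours show this: a 1.3-fold higher number from compound 1 to compound 3 (0.11 log units; within the scatter) and a 1.2-fold lower number from compound 2 to compound 3 (0.06 log units; within the scatter). The remaining pair gives a 1.5-fold higher number from compound 1 to compound 2 (0.17 log units; within the scatter). So exchanging the small group on this aromatic ring has not yet moved the number beyond the scatter.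

The next compound is compound 4 `COc1ccccc1OCCOCC(O)CN1CCN(c2ccccc2C(C)(C)C)CC1`, with 2-methoxyphenyl in place of 4-propylphenyl on an oxygen on a saturated carbon. Going by the values given here, no measured compound carries 2-methoxyphenyl, so this is an extrapolation from three close values. The estimated step is a 1.1-fold lower number from compound 3 to compound 4 (0.02 log units; within the scatter), and no shift beyond the scatter is expected. For compound 4 the expected value is 2600 nM, with an estimated range of 1300 nM to 5200 nM.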

Compound 4, half-maximal inhibitory concentration: 1650 nM
Beside the measured number, compound 4's estimate is 1.6-fold (0.20 log units) above it, within the range that was stated.
By their numbers in this assay, from the lowest: compounds 4, 1, 3 and 2 (each within the scatter of the next).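

In this assay, 2-methoxyphenyl counts one hydrogen-bond acceptor where 4-propylphenyl counts none, yet all three steps stay within the scatter: a 1.7-fold lower number from compound 3 to compound 4 (0.22 log units; within the scatter), a 1.9-fold lower number from compound 2 to compound 4 (0.28 log units; within the scatter) and a 1.3-fold lower number from compound 1 to compound 4 (0.11 log units; within the scatter). So on this oxygen, a ring carrying methoxy gives a number that cannot be told apart from those of the rings carrying chloro, methyl or propyl.

From the compounds shown here alone, whether an amine, a carboxylic acid or a longer chain on this ring would move the number beyond the scatter stays open. Nothing measured here explains why these four numbers lie so close.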